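The source may hold more compounds than are shown below. What is called first, only, known or untested is meant among the compounds shown, and "the series" means these compounds.

Measured so far:
compound 1, `COCCNC(=O)c1cc2cccc(OC)c2oc1=N` — > 70%
compound 2, `N=c1oc2ccc(Br)cc2cc1C(=O)NCC(O)CO` — 11%

In an assay on CHO cells for displacement of a labelled ligand from adenosine receptor A1 (Homo sapiens), read by scintillation counting, with a stated time of 60 min, tested at 10 uM (a lower number here means less inhibition, a higher number more inhibition at the concentration tested (going by the name of the read-out)), compound 1 gives > 70%. That value is a limit of the assay rather than a number, so compound 1 stands at the upper edge of what is shown: the limit of > 70% in this assay, at which 1 of the 2 values shown sits. Compound 2, which carries a different set of groups on the shared core, gives 11% in this assay. Among the compounds with values here, no pair of measured compounds differs in a single place, so no measured step is available to lean on.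

Compound 3, `COc1cccc2cc(C(=O)NCCO)c(=N)oc12`, differs from compound 1 in one place: hydrogen in place of methyl on an oxygen on a saturated carbon. Put another way, the 2-methoxyethyl chain on the amide becomes a 2-hydroxyethyl chain. Because compound 1 reached > 70%, a small step is expected, downward if anything, from compound 1 to compound 3 of a number no higher from compound 1 to compound 3 (the limit leaves the size open) in this assay. Compound 3 is therefore estimated to give 70%, within the range 45% to 90%.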

Compound 3, a percentage reported as inhibition, at one concentration (the size of the read-out at that concentration, not a potency): 47%
Beside the measured number, compound 3's estimate is 23 percentage points above it, within the range that was stated.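

In this assay, within the data shown here, the 2-methoxyethyl chain on the amide is the first place where a single change can be read, and turning it into a 2-hydroxyethyl chain gives a number at least 23 percentage points lower from compound 1 to compound 3 (beyond the scatter). So the methyl on that oxygen matters in this assay: replacing it with hydrogen is enough to move the read-out beyond the usual scatter. Only a minimum can be given for the size of this step, because compound 1 sits at a limit of the assay rather than at a number: the limit of > 70% in this assay, at which 1 of the 3 values shown sits.

On these data alone, it remains open how an amine or a carboxylic acid at the end of this chain, or a longer chain ending in methoxy, would compare. As far as these compounds go, compound 2 differs from compound 1 and compound 3 in more than one place, so whether this change would have the same effect with its other groups also remains open.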